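The source may hold more compounds than are shown below. What is called first, only, known or untested is meant among the compounds shown, and "the series" means these compounds.

Among the measured compounds shown here, in a functional assay on Caov-3 cells (Homo sapiens) for antiproliferative activity, read by CellTiter-Glo, with a stated time of 96 h (on this read-out higher numbers stand for weaker inhibition and lower numbers for stronger inhibition), compound 1 `COc1ccc(-c2nsc3c2NC(=O)CC3c2ccc3c(c2)OCCO3)cc1` gives 833 nM and compound 2 `COc1ccc(-c2nsc3c2NC(=O)CC3c2cccc(Cl)c2)cc1` gives 1300 nM and these two numbers lie within the scatter of each other, so compound 2 stands level with the only other measured compound. Compound 3 `COc1ccc(-c2nsc3c2NC(=O)CC3c2ccc(F)cc2)cc1` has 4-fluorophenyl in place of 3-chlorophenyl on a saturated ring carbon, with 4-fluorophenyl in place of 3-chlorophenyl on a saturated ring carbon as the counted difference. No measured step sizes this change. Different groups at that carbon show no separation beyond the scatter, with compound 1 at 833 nM and compound 2 at 1300 nM so no step beyond the scatter is expected in this assay in either direction. The estimated change is a 1.2-fold lower number from compound 2 to compound 3 (0.07 log units; within the scatter) and is expected to stay small. For compound 3 the expected value is 1100 nM within an estimated range of 450 nM to 2800 nM for a single measurement.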

Compound 3, half-maximal inhibitory concentration: > 2000 nM
Compound 3: a limit, no number; the forecaster's own chance of this, stated with the estimate: 3%; at least 1.8-fold (0.25 log units) between middle value and limit.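

In this assay compound 3 gives > 2000 nM, which is a limit of the assay and not a number. The step, an at least 1.5-fold higher number from compound 2 to compound 3 (0.18 log units; that floor lies within the scatter), gives only a floor, so 4-fluorophenyl in place of 3-chlorophenyl on a saturated ring carbon has no exact size, and it may or may not exceed the scatter. At this position a group change can now reach the end of the readable range: the limit of > 2000 nM in this assay, at which 1 of the 3 values shown sits.

The compounds shown leave open whether the halogen or its ring position governs the result. A 4-chlorophenyl or 3-fluorophenyl group would separate the two, and an aminophenyl group would test a different kind of substituent at that carbon.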